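This account rests on a few compounds, and the source may have more. Where it says the series, first, only, none or still open, it means among the compounds named here.

Compound 3 `CNC(=O)CCc1ccncc1-c1ccc2ccccc2c1` gives 21.1 nM in an assay on a protein complex for inhibition of CDK8/Cyclin C (Homo sapiens), with a stated time of 1 h (a lower number here means a stronger inhibitor, a higher number a weaker inhibitor), the highest of the three numbers. Compound 1 `CNC(=O)/C=C/c1ccncc1-c1ccc2ccccc2c1` gives 12.4 nM and compound 2 `O=C(O)/C=C/c1ccncc1-c1ccc2ccccc2c1` gives 5 nM. Compound 4 `NC(=O)/C=C/c1ccncc1-c1ccc2ccccc2c1` differs from compound 3 by 2-carbamoylethenyl in place of 2-(methylcarbamoyl)ethyl on an aromatic carbon. Among the measured compounds shown here, two measured steps bear on this change. The step of a 1.7-fold higher number from compound 1 to compound 3 (0.23 log units; within the scatter) shows that the saturated chain in place of the ethenyl chain changes little, so the reverse move is expected to be small. For the measured compounds named here, the step of a 4.2-fold higher number from compound 2 to compound 3 (0.63 log units; beyond the scatter) and the step of a 2.5-fold lower number from compound 1 to compound 2 (0.39 log units; beyond the scatter) show that the ethenyl amide and acid sit lower, while no measured pair shows the methylamino to amino exchange alone. Compound 4 is therefore estimated at 10 nM in this assay, between 4 nM and 25 nM, a step of a 2.1-fold lower number from compound 3 to compound 4 (0.32 log units; beyond the scatter) that is expected to be modest.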

Compound 4, half-maximal inhibitory concentration: 10.5 nM
Compound 4: the middle estimate sits 1.1-fold (0.02 log units) below what was measured, and the stated range covers the measured number.
By their numbers in this assay, from the lowest: compound 2; then compounds 4, 1 and 3 (each within the scatter of the next).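

In this assay, among the compounds shown here, the step of a 1.2-fold lower number from compound 1 to compound 4 (0.07 log units; within the scatter) is the first direct reading of hydrogen in place of methyl on the amide-type nitrogen, and it lies within the scatter, as does a 2.0-fold lower number from compound 3 to compound 4 (0.30 log units; within the scatter) for the full change of chain. Amino in place of hydroxy on the carbonyl carbon, seen in a 2.1-fold higher number from compound 2 to compound 4 (0.32 log units; beyond the scatter) beyond the scatter, is a modest step that separates the acid from this amide. No measurement shown gives a reason for these steps. Open still is how an ester on that carbonyl carbon, or a longer chain on this aromatic carbon, would read in this assay against these four compounds.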